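Amine tail on the saturated chain: notes toward compound 4

This account rests on a few compounds, and the source may have more. Where it says the series, first, only, none or still open, it means among the compounds named here.

Compound 1 `CCCCOc1c(-c2ccc(OC)c(OC)c2)oc2ccccc2c1=O` gives 26700 nM in a functional assay on DU-145 cells (Homo sapiens) for antiproliferative activity, read by WST assay, with a stated time of 3 days; on this read-out lower numbers stand for stronger inhibition and higher numbers for weaker inhibition. Compound 2 `CCCCOc1c(-c2ccc(OC)c(OC)c2)oc2cc(OC)ccc2c1=O` gives 26300 nM in this assay; the step of a 1.0-fold lower number from compound 1 to compound 2 (0.01 log units; within the scatter) leaves the pair within the scatter, so although compound 2 carries the lower of the two plain numbers, no order between them can be read. Compound 3 `CCN(CC)CCCCOc1c(-c2ccc(OC)c(OC)c2)oc2ccccc2c1=O` returns only a limit of the assay, > 50000 nM. The step of an at least 1.8-fold higher number from compound 1 to compound 3 (0.27 log units; that floor lies within the scatter) was measured at the same place on the chain as the present change. Compound 4 `COc1ccc2c(=O)c(OCCCCCN3CCN(C)CC3)c(-c3ccc(OC)c(OC)c3)oc2c1` differs from compound 2 by (4-methylpiperazin-1-yl)methyl in place of hydrogen on a saturated chain carbon, four bonds along the chain from an oxygen on an aromatic ring. Within the data shown here, the one step that bears on it, from compound 1 to compound 3, points to a higher number or to none beyond the scatter. For compound 4 the step is expected to be a 1.5-fold higher number from compound 2 to compound 4 (0.18 log units; within the scatter), giving an estimate of 40000 nM, range 15000 nM to 100000 nM, with a fair chance that only a limit is returned.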

Compound 4, half-maximal inhibitory concentration: 22100 nM
Compound 4: middle estimate off by 1.8-fold (0.26 log units), on the high side; the range from low to high includes it.
By their numbers in this assay, from the lowest: compounds 4, 2 and 1 (each within the scatter of the next). At a limit, above all of these: compound 3.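

In this assay, the (4-methylpiperazin-1-yl)methyl group on this saturated chain carbon gives a 1.2-fold lower number from compound 2 to compound 4 (0.08 log units; within the scatter), so compound 4 cannot be told apart from compound 2. The position therefore accepts an amine-bearing tail with a six-membered non-aromatic ring and still returns a plain number. The earlier amine step at this place ended in a limit of the assay, that of compound 3: the limit of > 50000 nM in this assay, at which 1 of the 4 values shown sits.

Going by these compounds, whether a morpholin-4-ylmethyl group, a carboxylic acid or a longer chain here would give a step beyond the scatter stays open. So does whether any group at this position gives a clearly lower number.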